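Pyridine amidrazone thiosemicarbazides: methyl step on the ring

The compounds below may be only part of what the source reports. "The series", "measured", "known", "first", "only" and "open" are said of these compounds alone.

Measured so far:
compound 1 `N/C(=N\NC(=S)N1CCCCCC1)c1ccccn1`: 76.5%
compound 2 `N/C(=N\NC(=S)N1CCOCC1)c1ccccn1`: 78.1%
compound 3 `Cc1ccnc(/C(N)=N/NC(=S)N2CCOCC2)c1`: 8.16%

In a functional assay on MCF7 cells (Homo sapiens) for cytotoxicity, read by MTT assay, with a stated time of 72 h, tested at 30 uM (a higher number here means more inhibition of growth at the concentration tested, a lower number less inhibition of growth), compound 1 gives 76.5% and compound 2 gives 78.1%; these two lie within the scatter of each other. How the cores of compound 1 and compound 2 differ is not broken down here. Compound 3 gives 8.16%, and the step of a number 69.9 percentage points lower from compound 2 to compound 3 (beyond the scatter) is methyl in place of hydrogen on an aromatic carbon. The not yet measured compound 4 `Cc1ccnc(/C(N)=N/NC(=S)N2CCCCCC2)c1` carries the same change against compound 1, (methyl in place of hydrogen on an aromatic carbon); the two place descriptions agree word for word, so it is the same kind of change at the same kind of place, seen only once so far. Among the compounds with values here, because the one measured example of this change, a number 69.9 percentage points lower from compound 2 to compound 3 (beyond the scatter), was large, a step of similar size is expected from compound 1, a number 64.5 percentage points lower from compound 1 to compound 4 (beyond the scatter). Compound 4 is therefore estimated at 12% in this assay, between 0% and 45%.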

Compound 4, percent growth inhibition at one concentration: 75.9%
Estimate against measurement, compound 4: 63.9 percentage points below; the measured number lies above the stated range.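

In this assay the new step is a number 0.6 percentage points lower from compound 1 to compound 4 (within the scatter), so methyl in place of hydrogen on an aromatic carbon does not carry a fixed size of step from one core to another in this series: the same change on two cores in this assay, a number 69.9 percentage points lower (beyond the scatter) from compound 2 to compound 3 and a number 0.6 percentage points lower (within the scatter) from compound 1 to compound 4, 69.3 percentage points apart, beyond the scatter of two such steps

The same change is thus tolerated on the core of compound 1 and not on the core of compound 2. Which difference between the two cores separates the steps is not shown, and two pairs give no rule for a third core.

Open, going by these compounds, is how an ethyl, a methoxy or a chlorine at the same place would behave on each core. Also open is whether a third amine in place of the two shown would follow compound 1 or compound 2.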